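Hydrazone aryl swap in the chloropyrimidine series

The compounds below may be only part of what the source reports. "The series", "measured", "known", "first", "only" and "open" are said of these compounds alone.

Within the data shown here, compound 3 `C/C(=N\Nc1ncc(Cl)c(Nc2cccc(NC(=O)/C=C/CN(C)C)c2)n1)c1ccc(F)cc1F` sits at the low end of the three numbers so far in an ADME assay on HT-29 cells (Homo sapiens) for inhibition, read by MTT assay, with a stated time of 72 h (a higher number here means a weaker inhibitor, a lower number a stronger inhibitor), giving 3460 nM. Compound 1 `CN(C)C/C=C/C(=O)Nc1cccc(Nc2nc(N/N=C/c3ccccc3F)ncc2Cl)c1` gives 3660 nM in this assay, and the step of a 1.1-fold lower number from compound 1 to compound 3 (0.02 log units; within the scatter) keeps the two together. Compound 2 `CN(C)C/C=C/C(=O)Nc1cccc(Nc2nc(N/N=C/c3ccncc3)ncc2Cl)c1` gives 25200 nM in this assay, and the step of a 7.3-fold lower number from compound 2 to compound 3 (0.86 log units; beyond the scatter) sets compound 3 apart from compound 2 only.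

Compound 4 `C/C(=N\Nc1ncc(Cl)c(Nc2cccc(NC(=O)/C=C/CN(C)C)c2)n1)c1ccncc1` is not yet measured. It differs from compound 3 as pyridin-4-yl in place of 2,4-difluorophenyl on a carbon with a double bond to nitrogen. The measured step that bears directly on this is a 6.9-fold higher number from compound 1 to compound 2 (0.84 log units; beyond the scatter), the same ring swap on a carbon with a double bond to nitrogen, there with 2-fluorophenyl as the leaving group. The step of a 1.1-fold lower number from compound 1 to compound 3 (0.02 log units; within the scatter) shows that moving from the group of 9 heavy atoms to the group of 11 heavy atoms on the hydrazone nitrogen changed nothing beyond the scatter, so the swap to pyridin-4-yl is expected to carry over. A step of similar size and direction is therefore expected in this assay, a 6.9-fold higher number from compound 3 to compound 4 (0.84 log units; beyond the scatter). Compound 4 is estimated at 24000 nM, with a range from 8000 nM to 70000 nM.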

Compound 4, half-maximal inhibitory concentration: 10900 nM
The estimate for compound 4 lay 2.2-fold (0.34 log units) above the measured number; low and high end bracket the measured number.
By their numbers in this assay, from the lowest: compounds 3 and 1 (each within the scatter of the next); then compound 4; then compound 2.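

In this assay, pyridin-4-yl again raises the number relative to a fluorinated phenyl on a carbon with a double bond to nitrogen (a 3.2-fold higher number from compound 3 to compound 4 (0.50 log units; beyond the scatter)), so the direction seen in a 6.9-fold higher number from compound 1 to compound 2 (0.84 log units; beyond the scatter) also holds when that carbon carries a saturated chain carbon, though this step is the smaller of the two. The pyridin-4-yl pair shows a gain that the fluorophenyl pair did not, since a 2.3-fold lower number from compound 2 to compound 4 (0.36 log units; beyond the scatter) lies beyond the scatter while a 1.1-fold lower number from compound 1 to compound 3 (0.02 log units; within the scatter) does not, although the latter step also adds a fluorine to the ring; the cost of pyridin-4-yl on the same carbon framework is then also visible across a 3.0-fold higher number from compound 1 to compound 4 (0.47 log units; beyond the scatter). No measurement shown accounts for these differences.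

Still open, as far as these compounds go, is whether the ring nitrogen itself carries the loss, which a phenyl or pyridin-3-yl ring on this carbon would help to test. Also open, from the compounds shown here alone, is whether an ethyl group in place of the saturated chain carbon would extend the gain seen with pyridin-4-yl or leave the number within the scatter.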